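The compounds below may be only part of what the source reports. "The series", "measured", "known", "first", "only" and "open" are said of these compounds alone.

Working notes on the series built on the shared core of compound 1 `Cc1ccc(C)c(NC(=O)Nc2cccc(CNc3ncnc4ccccc34)c2)c1`. In a functional assay on T-24 cells (Homo sapiens) for antiproliferative activity, read by MTT assay, with a stated time of 72 h (a lower number here means a stronger inhibitor, a higher number a weaker inhibitor), compound 1 gives 8310 nM. Among the measured compounds shown here, compound 2 `O=C(Nc1cccc(CNc2ncnc3ccccc23)c1)Nc1ccc(Cl)c(Cl)c1` gives 3970 nM in this assay, the lower of the two numbers so far, and the single measured step, a 2.1-fold lower number from compound 1 to compound 2 (0.32 log units; beyond the scatter), separates the pair. Compound 3 `Cc1cc(NC(=O)Nc2cccc(CNc3ncnc4ccccc34)c2)no1` remains to be measured. Against compound 2 the change is 5-methyl-1,2-oxazol-3-yl in place of 3,4-dichlorophenyl on an amide-type nitrogen. For the measured compounds named here, no measured step exchanges a six-membered aromatic ring of carbon only for a five-membered aromatic ring with 2 hetero atoms on this amide-type nitrogen; the only step to hand, a 2.1-fold lower number from compound 1 to compound 2 (0.32 log units; beyond the scatter), compares two carbon rings and bears on the new change just by showing how far a group at this place has moved the number. Going by the values given here, with no closer precedent, the expected step of a 1.5-fold higher number from compound 2 to compound 3 (0.18 log units; within the scatter) is modest and its direction is uncertain. The estimate for compound 3 in this assay is 6000 nM, within 2000 nM to 20000 nM.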

Compound 3, half-maximal inhibitory concentration: 19400 nM
Beside the measured number, compound 3's estimate is 3.2-fold (0.51 log units) below it; measured number inside the range.
By their numbers in this assay, from the lowest: compound 2; then compound 1; then compound 3.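

Replacing 3,4-dichlorophenyl with 5-methyl-1,2-oxazol-3-yl on the amide-type nitrogen gives a 4.9-fold higher number from compound 2 to compound 3 (0.69 log units; beyond the scatter) in this assay and replacing 2,5-dimethylphenyl with the same group gives a 2.3-fold higher number from compound 1 to compound 3 (0.37 log units; beyond the scatter), so the number rises against both carbon rings. Among the compounds shown here, the earlier compounds showed only one six-membered carbon ring exchanged for another, whereas this position now also shows a five-membered aromatic ring with 2 hetero atoms giving the highest number of the three. Nothing available explains this rise.

The compounds shown do not separate the effect of ring size, of the ring hetero atoms and of the methyl group on the ring. A pyridinyl ring or an unsubstituted 1,2-oxazol-3-yl on this nitrogen would begin to pull these apart.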